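The compounds below may be only part of what the source reports. "The series", "measured", "known", "first", "only" and "open" are said of these compounds alone.

Working notes on the series, all on one shared core. In a physicochemical assay for lipophilicity, read by LC-MS, using the shake flask method, in phosphate buffer, measured as octanol-water partition, with a stated time of 2 h, at pH 7.4 (on this read-out lower numbers stand for lower lipophilicity and higher numbers for higher lipophilicity), compound 1 `OC[C@H]1O[C@H](Cn2cc(-c3cccc(Cl)c3)nn2)[C@@H](O)[C@@H](O)[C@@H]1O`, which carries 3-chlorophenyl, gives 0.68. Compound 2 `OC[C@H]1O[C@H](Cn2cc(-c3cccnc3)nn2)[C@@H](O)[C@@H](O)[C@@H]1O` stands only at a limit of the assay: < -1.5. It therefore has no exact place on the scale.

Compound 3 `OC[C@H]1O[C@H](Cn2cc(COc3ccccc3)nn2)[C@@H](O)[C@@H](O)[C@@H]1O` is changed at the same position, on an aromatic carbon of a five-membered aromatic ring with 3 nitrogen, with phenoxymethyl in place of pyridin-3-yl on an aromatic carbon. Going by the values given here, the one measured step at this position is a number at least 2.18 log units lower from compound 1 to compound 2 (beyond the scatter). Going by these compounds, that step is large, and its full size stays open. Among the compounds with values here, it is the only guide here, and it points to a large rise in this assay once pyridin-3-yl leaves and a six-membered aromatic ring of carbon only enters. The 3-chlorophenyl group does not return, so compound 3 is expected to close most, but not all, of the distance to compound 1 at 0.68.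

The estimated change is a number at least 1.30 log units higher from compound 2 to compound 3 (beyond the scatter), a rise expected to lie beyond the scatter. For compound 3 the expected value is -0.2, with an estimated range of -0.8 to 0.4.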

Compound 3, distribution coefficient: -0.83
Compound 3: the middle estimate sits 0.63 log units above what was measured; the whole stated range lies above it.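

Phenoxymethyl in place of 3-chlorophenyl on an aromatic carbon of the five-membered aromatic ring with 3 nitrogen gives a number 1.51 log units lower from compound 1 to compound 3 (beyond the scatter), the first step at this position in this assay with a full size rather than a bound. Phenoxymethyl in place of pyridin-3-yl gives a number at least 0.67 log units higher from compound 2 to compound 3 (beyond the scatter), so the six-membered aromatic ring of carbon only, which phenoxymethyl shares with 3-chlorophenyl, does not on its own bring the value back to that of compound 1. The full size of the rise from the pyridin-3-yl compound remains unknown, with compound 2 held at a limit: the limit of < -1.5 in this assay, at which 1 of the 3 values shown sits.

Phenoxymethyl and 3-chlorophenyl differ both in the chlorine on the ring and in the oxymethyl link to it, and the compounds shown do not separate these two changes. Going by these compounds, what an unsubstituted phenyl, a benzyl group, an amine or a carboxylic acid at this position would give in this assay stays open, as does whether the large steps seen here hold on any other core.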